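The compounds below may be only part of what the source reports. "The series", "measured", "known", "first", "only" and "open" are said of these compounds alone.

Measured compounds:
compound 1, `COc1cc(-c2nnc(SCc3cccc(Br)c3)o2)ccc1O`, in an ADME assay on cells (Mus musculus, strain BALB/c) for cytotoxicity, read by MTT assay, with a stated time of 24 h; on this read-out higher numbers stand for lower toxicity in this test and lower numbers for higher toxicity in this test: 382000 nM
compound 2, `COc1cc(-c2nnc(SCc3ccc(F)cc3)o2)ccc1O`, in this assay: 685000 nM
compound 3, `COc1cc(-c2nnc(SCc3ccccc3C)o2)ccc1O`, in this assay: 592000 nM

Compound 3 stands second highest of the three numbers. Its nearest neighbour is compound 2, a 1.2-fold lower number from compound 2 to compound 3 (0.06 log units; within the scatter); its furthest is compound 1, a 1.5-fold higher number from compound 1 to compound 3 (0.19 log units; within the scatter). All three measured steps, a 1.8-fold higher number from compound 1 to compound 2 (0.25 log units; within the scatter), a 1.5-fold higher number from compound 1 to compound 3 (0.19 log units; within the scatter) and a 1.2-fold lower number from compound 2 to compound 3 (0.06 log units; within the scatter), swap one substituted phenyl for another on a saturated chain carbon bound to a sulfur, and every one of them lies within the scatter. Within the data shown here, the series so far shows no step beyond the scatter at all.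

Compound 4, `COc1cc(-c2nnc(SCc3ccccc3C)o2)ccc1OCc1ccccc1C`, differs from compound 3 at a different place: 2-methylbenzyl in place of hydrogen on an oxygen on an aromatic ring. Among the measured compounds shown here, no measured step touches the oxygen on the aromatic ring, so none of the three steps bears directly on this change. The expectation for this assay therefore rests only on the spread of the measured series, and the step expected from compound 3 to compound 4 is a 1.3-fold lower number from compound 3 to compound 4 (0.12 log units; within the scatter), that is, no change beyond the scatter, with a wide range to reflect the lack of a directly comparable step. In this assay compound 4 is estimated to give 450000 nM, with a range from 150000 nM to 1200000 nM.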

Compound 4, half-maximal cytotoxic concentration: 195000 nM
Beside the measured number, compound 4's estimate is 2.3-fold (0.36 log units) above it; measured number inside the range.
By their numbers in this assay, from the lowest: compounds 4, 1, 3 and 2 (each within the scatter of the next, the first and the last beyond it).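

Among these compounds, the step of a 3.0-fold lower number from compound 3 to compound 4 (0.48 log units; beyond the scatter) in this assay is the first to lie beyond the scatter. It comes with 2-methylbenzyl in place of hydrogen on an oxygen on an aromatic ring, so this oxygen is a place where the number moves, modestly and towards higher toxicity in this test, whereas the three swaps of one substituted phenyl for another on a saturated chain carbon bound to a sulfur all stayed within the scatter. No measurement at hand bears on why the number falls at this oxygen.

A single change at this oxygen leaves open whether the drop follows from replacing the hydroxy hydrogen at all or from the 2-methylbenzyl group itself; an unsubstituted benzyl, an ethyl group or a longer chain ending in an amine or a carboxylic acid on the same oxygen would separate the two. Also open, from the compounds shown here alone, is whether swaps on the saturated chain carbon bound to a sulfur stay within the scatter once the oxygen carries 2-methylbenzyl, since compound 4 is the only such case here.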